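A Dichlorophenyl Swap Tested at a Single Low Concentration

The compounds below may be only part of what the source reports. "The series", "measured", "known", "first", "only" and "open" are said of these compounds alone.

Compound 1 has the structure `COc1cc(-c2cc(/C=C/C(=O)c3ccc(N)cc3)[nH]n2)cc(OC)c1OC`. In a functional assay on K562 cells (Homo sapiens) for cytotoxicity, read by sulforhodamine B assay, with a stated time of 48 h, tested at 0.1 uM (on this read-out higher numbers stand for a weaker effect at the one concentration tested and lower numbers for a stronger effect), compound 1 gives 94%. Within the data shown here, compound 2, with the structure `COc1ccc(-c2cc(/C=C/C(=O)c3ccc(OC)c(OC)c3)[nH]n2)cc1`, is the only other compound measured, and in this assay compound 2 gives 108%. On these two numbers compound 1 stands lowest, and the nearest number, that of compound 2, lies higher by an amount beyond the usual scatter, so compound 1 shows the stronger effect of the two at the one concentration tested.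

Compound 3, with the structure `COc1cc(-c2cc(/C=C/C(=O)c3ccc(Cl)c(Cl)c3)[nH]n2)cc(OC)c1OC`, has not yet been measured in this assay. It differs from compound 1 in one place: 3,4-dichlorophenyl in place of 4-aminophenyl on a carbonyl carbon. Among the measured compounds shown here, no step between two measured compounds that differ in one place is available to guide this change, and compound 2 differs from compound 1 in more than one place, so only its own number can be set beside that of compound 1. The step of a number 1 percentage points higher from compound 1 to compound 3 (within the scatter) is expected to be small and not beyond the scatter, since both measured numbers sit close to no effect. Compound 3 is therefore estimated at 95%, within a range from 80% to 110%.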

Compound 3, a percentage reported as activity, at one concentration (the size of the read-out at that concentration, not a potency): 106%
Compound 3: middle estimate off by 11 percentage points, on the low side; the measured number falls inside the stated range.
By their numbers in this assay, from the lowest: compound 1; then compounds 3 and 2 (each within the scatter of the next).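

Among these compounds, replacing 4-aminophenyl with 3,4-dichlorophenyl on a carbonyl carbon gives the first step in this assay that can be read at a single place, and it is a number 12 percentage points higher from compound 1 to compound 3 (beyond the scatter) on the shared core, a modest move toward a weaker effect at the one concentration tested. This place is therefore not wholly indifferent to its substituent, and of these two groups the 4-aminophenyl goes with the stronger effect, although the change removes the hydrogen-bond donor and acceptor of the 4-aminophenyl and brings in chlorine at the same time, so this single step cannot separate the two. No measurement on hand accounts for the step.

The compounds shown leave open whether the amine or the chlorine atoms carry the difference, a question that an unsubstituted phenyl, a 4-hydroxyphenyl or a 4-dimethylaminophenyl at this place could help to settle. They also leave open whether the step would hold at higher concentrations, where a larger effect could be read than this one low concentration allows.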